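Thiazole imines: phenyl versus methyl on the thiazole carbon

This account rests on a few compounds, and the source may have more. Where it says the series, first, only, none or still open, it means among the compounds named here.

Measured so far:
compound 1, `Cc1ccccc1/C=N/c1nc(-c2ccccc2)cs1`, 66.1 nM
compound 2, `Cc1ccc(/C=N/c2nc(C)cs2)cc1`, 204 nM

Both values come from an assay on mitochondria for inhibition of Amine oxidase [flavin-containing] A (Bos taurus); on this read-out lower numbers stand for stronger inhibition and higher numbers for weaker inhibition. Among the compounds with values here, compound 2 stands at the higher of the two numbers; compound 1 differs from it in more than one place, so no single step links them, and the two values only show that compound 1 sits beyond the scatter on the lower side.

Compound 3, `Cc1ccc(/C=N/c2nc(-c3ccccc3)cs2)cc1`, is not yet measured. It differs from compound 2 by phenyl in place of methyl on an aromatic carbon. Compound 1, which also carries the phenyl on the core and gives 66.1 nM, suggests the direction, though its other difference from compound 2 leaves the size uncertain. A modest step to a lower number is expected, a 2.6-fold lower number from compound 2 to compound 3 (0.41 log units; beyond the scatter), likely beyond the scatter but not certainly so. For compound 3 the estimate is 80 nM, with a range from 25 nM to 250 nM.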

Compound 3, inhibition constant: 21.4 nM
Compound 3: middle estimate off by 3.7-fold (0.57 log units), on the high side; measured number outside the range, below it.
By their numbers in this assay, from the lowest: compound 3; then compound 1; then compound 2.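

In this assay, phenyl in place of methyl on the aromatic carbon next to the ring nitrogen gives a 9.5-fold lower number from compound 2 to compound 3 (0.98 log units; beyond the scatter) with nothing else in the structure changed. Within the data shown here, this is the first single-place reading at this carbon, and it shows that the position accepts a six-membered aromatic ring of carbon only, with a lower number than methyl gives. No measurement shown here accounts for the step.

Going by these compounds, with only these two groups compared at this carbon, it remains open how a hydrogen, a cyclohexyl ring, a longer alkyl chain, or an amine would read there. Also open, on these data alone, is whether a phenyl carrying a methoxy or a chloro group would extend the step or reverse it.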